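Swapping the outer ring in a trifluoromethyl-pyrrolidine series

The compounds below may be only part of what the source reports. "The series", "measured", "known", "first", "only" and "open" are said of these compounds alone.

Measured so far:
Compound 1, `O=C(O)C[C@@H]1CCCN1c1ccc(Oc2cccc(Cl)c2)cc1`: 680 nM
Compound 2, `Cc1cc(OCc2ccccc2)ccc1Oc1ccc(N2C[C@@H](C(F)(F)F)C[C@H]2CC(=O)O)cc1`: 120 nM
Compound 3, `COc1ccc(Oc2ccc(N3C[C@@H](C(F)(F)F)C[C@H]3CC(=O)O)cc2)c(C)c1`: 55 nM

In a functional assay on cells for agonist activity at Free fatty acid receptor 1 (Homo sapiens), read by FLIPR and calcium flux, with a stated time of 100 s (a higher number here means that more compound is needed for the effect, a lower number that less compound is needed), compound 3 gives 55 nM, the lowest of the three numbers; compound 2 sits closest, and compound 1, which lacks the trifluoromethyl group on the shared core, is furthest away. For the measured compounds named here, the one measured step that changes a single place, a 2.2-fold lower number from compound 2 to compound 3 (0.34 log units; beyond the scatter), concerns the group on the oxygen on the aromatic ring, so it is the only comparison that touches the same region.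

Compound 4, `Cc1cccc(C)c1Oc1ccc(N2C[C@@H](C(F)(F)F)C[C@H]2CC(=O)O)cc1`, differs from compound 3 by 2,6-dimethylphenyl in place of 4-methoxy-2-methylphenyl on an oxygen on an aromatic ring. Going by the values given here, no measured pair shows this exact exchange, so the expectation rests only on the observation that altering this outer ring moved the number modestly in the one step seen. A small shift, in either direction, is the most that can be read from the data.

Compound 4 is therefore expected to give about 100 nM in this assay, within a range of 35 nM to 300 nM. That estimate corresponds to an expected step of a 1.8-fold higher number from compound 3 to compound 4 (0.26 log units; within the scatter).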

Compound 4, half-maximal effective concentration: 82 nM
Compound 4: middle estimate off by 1.2-fold (0.09 log units), on the high side; the range from low to high includes it.
By their numbers in this assay, from the lowest: compounds 3, 4 and 2 (each within the scatter of the next, the first and the last beyond it); then compound 1.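

On an oxygen on an aromatic ring, 2,6-dimethylphenyl can take the place of 4-methoxy-2-methylphenyl with the two results staying indistinguishable in this assay: the step is a 1.5-fold higher number from compound 3 to compound 4 (0.17 log units; within the scatter). Compounds 2 and 3 both carry an oxygen on this outer ring, whereas the 2,6-dimethylphenyl group of compound 4 is carbon only and has no hydrogen-bond acceptor, so in this pair that oxygen is not needed to keep the number in this range. Nothing measured here explains why the two groups read alike.

This exchange removes the methoxy group and adds a methyl group at once, so the contribution of each remains unseparated. On these data alone, it also remains open how this outer ring would respond to an amine, a nitrile or a fluorine.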